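Dimethylamino for ethylamino on a thiocarbonyl carbon

A few compounds are considered here, and "the series" means these few. Any claim that something is new, unique, unknown or untested is made for them only; others in the source may bear on it.

- compound 1 `CCNC(=S)SCC1=CCOC1=O` gives 44400 nM in the test below
- compound 2 `CN1CCN(C(=S)SCC2=CC(=O)OC2)CC1` gives 35800 nM in the test below

Both numbers come from a functional assay on EC9706 cells (Homo sapiens) for antiproliferative activity, read by MTT assay, with a stated time of 72 h (a higher number here means a weaker inhibitor, a lower number a stronger inhibitor), and they lie within the usual scatter of each other. Compound 1 therefore stands level with compound 2, and the two cannot be ranked.

Compound 3 `CN(C)C(=S)SCC1=CCOC1=O` has not yet been measured in this assay and is built from the same atoms as compound 1, joined differently. The change is dimethylamino in place of ethylamino on a thiocarbonyl carbon, counted as dimethylamino in place of ethylamino on a thiocarbonyl carbon for this swap.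

Among the measured compounds shown here, no measured pair shows what such a swap does, so any forecast here is rough. The closest anchor is compound 1 at 44400 nM in this test, and no step beyond the scatter is expected, in either direction. The expected move is a 1.1-fold lower number from compound 1 to compound 3 (0.05 log units; within the scatter) and would stay within that scatter. For compound 3 the estimated value is 40000 nM with an expected range from 18000 nM to 90000 nM across repeat measurements.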

Compound 3, half-maximal inhibitory concentration: 182000 nM
Beside the measured number, compound 3's estimate is 4.6-fold (0.66 log units) below it; the measured number lies above the stated range.
By their numbers in this assay, from the lowest: compounds 2 and 1 (each within the scatter of the next); then compound 3.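

In this assay, placing dimethylamino in place of ethylamino on a thiocarbonyl carbon gives a 4.1-fold higher number from compound 1 to compound 3 (0.61 log units; beyond the scatter) and so counts as a real, though modest, loss of activity. This shows that the position is sensitive even to a change that leaves the heavy-atom count and the atoms themselves the same. By the computed counts, ethylamino has a hydrogen-bond donor and dimethylamino does not, but no measurement here ties the step to that difference, so its cause remains unknown.

This single pair cannot show whether the hydrogen on the nitrogen is what matters: methylamino would keep that hydrogen with a smaller group, and propylamino would keep it on a longer chain, so either could help separate the two possibilities. As far as these compounds go, compound 2 differs from compound 3 in more than one place, so it cannot show whether the same swap would have a similar effect on another core, and that question also stays open.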